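A few compounds are considered here, and "the series" means these few. Any claim that something is new, unique, unknown or untested is made for them only; others in the source may bear on it.

Among the compounds with values here, in an assay on CHO cells for displacement of a labelled ligand from melanin-concentrating hormone receptor 1 (Rattus norvegicus), read by scintillation counting, with a stated time of 1 h (on this read-out higher numbers stand for weaker inhibition and lower numbers for stronger inhibition), compound 2 `Cc1c(C2CC2)nc2ccc(-n3ccc(OCc4ccc(F)cc4)cc3=O)cn12` gives 28 nM, the higher of the two numbers measured so far. Compound 1 `Cc1c(C2CC2)nc2ccc(NC(=O)COc3ccc(OC(F)(F)F)cc3)cn12` gives 6.3 nM in this assay. Compound 3 `COCc1nc2ccc(-n3ccc(OCc4ccc(F)cc4)cc3=O)cn2c1C` reaches only a limit, > 1000 nM, in this assay, so no number is known for it. The step of an at least 35-fold higher number from compound 2 to compound 3 (1.55 log units; beyond the scatter) sits on the shared core, and its end is set by the limit of > 1000 nM in this assay, at which 1 of the 3 values shown sits. Compound 4 `Cc1c(C2CC2)nc2ccc(-n3ccc(OCc4ccccn4)cc3=O)cn12` differs from compound 2 in a different part of the molecule: pyridin-2-yl in place of 4-fluorophenyl on a saturated chain carbon bound to an oxygen on an aromatic ring. Within the data shown here, no measured step touches this part, so the earlier steps give no direct guide. The change is expected to leave the number near that of compound 2, with a 1.6-fold higher number from compound 2 to compound 4 (0.21 log units; within the scatter) no larger than the usual scatter. Compound 4 is therefore estimated at 45 nM, between 12 nM and 200 nM.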

Compound 4, half-maximal inhibitory concentration: 150 nM
The estimate for compound 4 lay 3.3-fold (0.52 log units) below the measured number; low and high end bracket the measured number.
By their numbers in this assay, from the lowest: compound 1; then compound 2; then compound 4. At a limit, above all of these: compound 3.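

The aromatic ring at the end of the ether chain matters to binding: pyridin-2-yl in place of 4-fluorophenyl gives a 5.4-fold higher number from compound 2 to compound 4 (0.73 log units; beyond the scatter) in this assay. This is the first step shown in this part of the molecule, and it stays modest. Nothing shown gives a reason for it.

On these data alone, the swap removes the fluorine and adds a ring nitrogen together, so their separate contributions remain unknown. As far as these compounds go, an unsubstituted phenyl ring could separate them, and how a longer chain at this place would behave also remains open.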